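The source may hold more compounds than are shown below. What is called first, only, known or untested is meant among the compounds shown, and "the series" means these compounds.

Series notes. The shared core of compound 1 `COc1ccc(CN2CCC(C(=O)Nc3cc(Cl)c(N)cc3OC)CC2)cc1` is kept throughout; the variation sits on the aromatic ring carried by the carbon bound to the ring amine nitrogen. In a functional assay on the whole organism for antagonist activity, with Mus musculus as the target (a higher number here means that more compound is needed for the effect, a lower number that less compound is needed), compound 1 gives 0.9 mg/kg. Compound 2 `COc1cc(N)c(Cl)cc1NC(=O)C1CCN(Cc2ccc(C)c(C)c2)CC1` carries 3,4-dimethylphenyl at that position. In this assay compound 2 reaches only the limit of the assay, > 8 mg/kg, and no number. Compound 3 `COc1cc(N)c(Cl)cc1NC(=O)C1CCN(Cc2ccc(F)cc2)CC1` carries 4-fluorophenyl, and in this assay compound 3 gives 0.6 mg/kg. Compound 3 thus sits alongside compound 1 within the scatter, the two values separated by a 1.5-fold lower number from compound 1 to compound 3 (0.18 log units; within the scatter); the third value shown is a limit (the limit of > 8 mg/kg in this assay, at which 1 of the 3 values shown sits). The steps of an at least 8.8-fold higher number from compound 1 to compound 2 (0.94 log units; beyond the scatter) and an at least 13-fold lower number from compound 2 to compound 3 (1.12 log units; beyond the scatter) are the only ones beyond the scatter.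

Compound 4 `COc1cc(N)c(Cl)cc1NC(=O)C1CCN(Cc2ccccc2)CC1` differs from compound 3 by hydrogen in place of fluoro on an aromatic carbon. The step that bears most directly on it is a 1.5-fold lower number from compound 1 to compound 3 (0.18 log units; within the scatter), where an exchange at the same aromatic carbon left the number within the scatter; the large steps involve 3,4-dimethylphenyl and do not concern a single substituent at this position. The expectation for compound 4 is therefore a step of a 1.3-fold higher number from compound 3 to compound 4 (0.12 log units; within the scatter) in this assay, not beyond the scatter in either direction. Compound 4 is estimated at 0.8 mg/kg in this assay, within 0.3 mg/kg to 2.5 mg/kg.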

Compound 4, dose for half-maximal effect: 0.5 mg/kg
Beside the measured number, compound 4's estimate is 1.6-fold (0.20 log units) above it, and the stated range covers the measured number.
By their numbers in this assay, from the lowest: compounds 4, 3 and 1 (each within the scatter of the next). At a limit, above all of these: compound 2.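

Hydrogen in place of fluoro on the aromatic carbon gives a 1.2-fold lower number from compound 3 to compound 4 (0.08 log units; within the scatter), and hydrogen in place of methoxy gives a 1.8-fold lower number from compound 1 to compound 4 (0.26 log units; within the scatter). Compound 1 and compound 3 both carried a group at this carbon, whereas compound 4 shows that in this assay the phenyl, 4-fluorophenyl and 4-methoxyphenyl compounds cannot be told apart, so neither fluoro nor methoxy is needed here for a value in this range. Compound 2 has a limit and not a number, so an at least 16-fold lower number from compound 2 to compound 4 (1.20 log units; beyond the scatter) is open on one side, and with phenyl as the reference the break in this short series lies with 3,4-dimethylphenyl and not with the absence of a group at the aromatic carbon: the limit of > 8 mg/kg in this assay, at which 1 of the 4 values shown sits.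

Going by these compounds, it remains open whether an amine or a carboxylic acid on this aromatic carbon would stay within the scatter of compound 4. On these data alone, it also remains open whether 4-methylphenyl or 3-methylphenyl alone would follow phenyl or 3,4-dimethylphenyl, and the size of the break cannot be fixed while compound 2 has only a limit.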